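Replacing naphthalen-1-yl with 3,5-dichlorophenyl on a thiourea nitrogen

This account rests on a few compounds, and the source may have more. Where it says the series, first, only, none or still open, it means among the compounds named here.

Compound 2 `NC(=S)Nc1cccc(OCCCCCNC(=S)Nc2cccc3ccccc23)c1` carries a naphthalen-1-yl group on an amide-type nitrogen whose other neighbour is a thiocarbonyl carbon. In an ADME assay on Huh-7 cells (Homo sapiens) for cytotoxicity (a higher number here means that more compound is tolerated, a lower number that less compound is tolerated), compound 2 gives > 50000 nM, which is a limit of the assay rather than a number. Its partner compound 1 `NC(=S)Nc1cccc(OCCCCCNC(=S)Nc2ccc(Cl)cc2)c1` is the 4-chlorophenyl analogue. In this assay compound 1 gives > 50000 nM, again a limit. The step that the two limits leave unreadable from compound 1 to compound 2 therefore cannot be read, because the limit of > 50000 nM in this assay, at which 2 of the 2 values shown sit, is where both values sit.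

Compound 3 `NC(=S)Nc1cccc(OCCCCCNC(=S)Nc2cc(Cl)cc(Cl)c2)c1` differs from compound 2 by 3,5-dichlorophenyl in place of naphthalen-1-yl on an amide-type nitrogen. Going by the values given here, no measured step bears on this change, since the only step recorded is unreadable. Compound 3 is accordingly expected to remain at the limit, with an estimate of 50000 nM in a range from 20000 nM to 100000 nM. The expected step of a number no higher from compound 2 to compound 3 (the limit leaves the size open) amounts to no change beyond the scatter.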

Compound 3, half-maximal cytotoxic concentration: 18000 nM
Compound 3: middle estimate off by 2.8-fold (0.44 log units), on the high side, and the stated range ends above it.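

In this assay, the group on the amide-type nitrogen turns out to matter: 3,5-dichlorophenyl in place of naphthalen-1-yl gives an at least 2.7-fold lower number from compound 2 to compound 3 (0.44 log units; beyond the scatter), and in place of 4-chlorophenyl it gives an at least 2.7-fold lower number from compound 1 to compound 3 (0.44 log units; beyond the scatter). Of the three groups shown at this place, only 3,5-dichlorophenyl yields a number rather than a limit, so less compound is tolerated with this group than with either of the others. The full size of both steps stays open because the starting end of each is a limit rather than a number: the limit of > 50000 nM in this assay, at which 2 of the 3 values shown sit.

The compounds shown leave open whether a single chlorine at another place on the phenyl ring, or a trifluoromethyl group in place of the two chlorines, would also bring a number. They also leave open how a longer chain in the shared core would read in this assay alongside 3,5-dichlorophenyl.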